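A few compounds are considered here, and "the series" means these few. Any claim that something is new, unique, unknown or untested is made for them only; others in the source may bear on it.

Values in a functional assay on HL-60 cells (Homo sapiens) for cytotoxicity, read by WST assay, with a stated time of 48 h; a lower number here means that less compound is needed, a higher number that more compound is needed for the effect:

compound 1 `O=C1OC[C@H](Cc2ccccc2)[C@H]1Cc1cccc(O)c1`: > 100000 nM, a limit of the assay.
compound 2 `COc1cccc(C[C@H]2C(=O)OC[C@@H]2Cc2ccccc2)c1`: 66000 nM.
compound 3 `O=C1OC[C@H](Cc2ccccc2)[C@H]1Cc1ccc(O)cc1`: 88000 nM.

Compound 3 stands highest of the two numbers, with compound 2 nearest within the scatter. From compound 1 to compound 2 the change is methyl in place of hydrogen on an oxygen on an aromatic ring, giving an at least 1.5-fold lower number from compound 1 to compound 2 (0.18 log units; that floor lies within the scatter). From compound 1 to compound 3 the core change is 4-hydroxyphenyl in place of 3-hydroxyphenyl on a saturated chain carbon bound to a saturated ring carbon, giving an at least 1.1-fold lower number from compound 1 to compound 3 (0.05 log units; that floor lies within the scatter); the first value rests on (the limit of > 100000 nM in this assay, at which 1 of the 3 values shown sits).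

Compound 4 `COc1ccc(C[C@H]2C(=O)OC[C@@H]2Cc2ccccc2)cc1` carries the same change as compound 2, namely (methyl in place of hydrogen on an oxygen on an aromatic ring), at a place worded identically. The step from compound 3 to compound 4 in this assay is expected to be a 1.8-fold lower number from compound 3 to compound 4 (0.25 log units; within the scatter), beside the earlier step of an at least 1.5-fold lower number from compound 1 to compound 2 (0.18 log units; that floor lies within the scatter), which gives only a floor. For compound 4 the expected value is 50000 nM, estimated between 25000 nM and 100000 nM.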

Compound 4, half-maximal effective concentration: 67000 nM
Estimate against measurement, compound 4: 1.3-fold (0.13 log units) below; low and high end bracket the measured number.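

In this assay, methyl in place of hydrogen on the oxygen on the aromatic ring gives a 1.3-fold lower number from compound 3 to compound 4 (0.12 log units; within the scatter). Set beside the same change on the core of compound 1, this shows neither that the change carries over with a size of its own nor that it behaves differently on the two cores: the same change on two cores in this assay, an at least 1.5-fold lower number (0.18 log units; that floor lies within the scatter) from compound 1 to compound 2 and a 1.3-fold lower number (0.12 log units; within the scatter) from compound 3 to compound 4; the limit leaves it open whether they differ Compound 1 gives > 100000 nM, which is a limit of the assay.

Open is whether any other group at this oxygen moves the number beyond the scatter: a longer chain such as ethoxy, an amine or a carboxylic acid stands in none of the compounds shown. Also open, on these data alone, is how the change behaves on a core whose number lies clear of the limit.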